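A few compounds are considered here, and "the series" means these few. Any claim that something is new, unique, unknown or untested is made for them only; others in the source may bear on it.

Working notes on the series, read in a functional assay on KB cells (Homo sapiens) for antiproliferative activity, read by MTT assay, with a stated time of 48 h; on this read-out higher numbers stand for weaker inhibition and lower numbers for stronger inhibition. Compound 1 (`Cn1cc(C2=C(c3nn(CCCn4cncn4)c4ncccc34)C(=O)N(c3ccccc3)C2=O)c2ccccc21`) gives > 100000 nM, which is a limit of the assay. Compound 2 (`Cn1cc(C2=C(c3nn(CCCn4ccnc4)c4ncccc34)C(=O)N(c3ccccc3)C2=O)c2ccccc21`) gives 6800 nM. Compound 3 (`Cn1cc(C2=C(c3nn(CCCn4ccnc4)c4ncccc34)C(=O)NC2=O)c2ccccc21`) gives > 100000 nM, also a limit and not a number. The picture so far is marked by the limit of > 100000 nM in this assay, at which 2 of the 3 values shown sit.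

Compound 4 (`Cn1cc(C2=C(c3n[nH]c4ncccc34)C(=O)NC2=O)c2ccccc21`) has hydrogen in place of 3-(1H-imidazol-1-yl)propyl on an aromatic nitrogen. Within the data shown here, no measured step removes this whole chain, so the evidence is indirect. Changing the end of the chain gave an at least 14-fold lower number from compound 1 to compound 2 (1.16 log units; beyond the scatter). Replacing phenyl by hydrogen on an amide-type nitrogen in a ring gave an at least 14-fold higher number from compound 2 to compound 3 (1.16 log units; beyond the scatter). Both steps are large, and both show only a minimum size. They show that single changes can matter here, but they do not fix the direction of this one. With compound 3 at a limit, only a lower number could show a change, so at most a modest fall is expected. The expected change is an at least 1.2-fold lower number from compound 3 to compound 4 (0.09 log units; that floor lies within the scatter). For compound 4 the estimated value is 80000 nM, with an expected range from 15000 nM to 200000 nM.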

Compound 4, half-maximal inhibitory concentration: 62000 nM
The estimate for compound 4 lay 1.3-fold (0.11 log units) above the measured number; the measured number falls inside the stated range.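

Replacing 3-(1H-imidazol-1-yl)propyl by hydrogen on the aromatic nitrogen gave an at least 1.6-fold lower number from compound 3 to compound 4 (0.20 log units; that floor lies within the scatter). Among these compounds, with hydrogen on the amide-type nitrogen, the series therefore gives a measured number without this chain, which the earlier compounds could not show, as all of them carry a chain at this position. Compound 3 gives > 100000 nM, which is a limit and not a number, so the step is a floor only and its true size stays unfixed: the limit of > 100000 nM in this assay, at which 2 of the 4 values shown sit.

Going by these compounds, whether the same replacement acts alike when phenyl sits on the amide-type nitrogen remains open. Also open, on these data alone, is how a simple amine or a longer chain ending in a carboxylic acid would read on the same aromatic nitrogen.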